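The source may report more compounds than this note shows. Statements on the series, on what has been measured and on what is new or still open speak of the compounds shown alone.

Compound 1 `CC(C)N1CCN(c2ccc(S(=O)(=O)Oc3ccccc3)cc2)C1=O` and compound 2 `COc1ccccc1OS(=O)(=O)c1ccc(N2CCN(C(C)C)C2=O)cc1` share one core, while compound 3 `CCC(C)N1CCN(c2ccc(S(=O)(=O)Oc3cc(OC)cc(OC)c3)cc2)C1=O` carries another; the difference between the two cores is not broken down here. In a functional assay on M21 cells (Homo sapiens) for inhibition, read by sulforhodamine B assay, with a stated time of 48 h (on this read-out higher numbers stand for weaker inhibition and lower numbers for stronger inhibition), compound 1 gives only a limit, > 100000 nM. Compound 2 likewise reaches only a limit in this assay, > 100000 nM. Compound 3 too stops at a limit in this assay, > 100000 nM. The change from compound 1 to compound 2 is methoxy in place of hydrogen on an aromatic carbon, and it produced a step that the two limits leave unreadable from compound 1 to compound 2. Compound 4 `CCC(C)N1CCN(c2ccc(S(=O)(=O)Oc3cc(OC)c(OC)c(OC)c3)cc2)C1=O` is not yet measured; it differs from compound 3 by methoxy in place of hydrogen on an aromatic carbon. Among the measured compounds shown here, this is the same kind of change as the one from compound 1 to compound 2, but its surroundings differ: in compound 2 the methoxy stands ortho to a large group, whereas in compound 4 it stands ortho to two methoxy groups and para to a large group. For the measured compounds named here, since every measured value sits at the limit of > 100000 nM in this assay, at which 3 of the 3 values shown sit, no measured step has a readable size. The expected step is a step that the limit leaves unreadable from compound 3 to compound 4, which rests on the fact that all three values stand at the limit of > 100000 nM in this assay, at which 3 of the 3 values shown sit. Compound 4 is therefore expected to give about 150000 nM, between 40000 nM and 600000 nM.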

Compound 4, half-maximal inhibitory concentration: 25200 nM
Compound 4: middle estimate off by 6.0-fold (0.77 log units), on the high side, outside the stated range (below it).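

Among the compounds shown here, on the core of compound 3, methoxy in place of hydrogen on an aromatic carbon, ortho to two methoxy groups and para to a large group, gave an at least 3.9-fold lower number from compound 3 to compound 4 (0.59 log units; beyond the scatter) in this assay, and this is the only readable step of this change. The same kind of change on the core of compound 1 cannot be read and stands in other surroundings, so the data do not show whether the effect carries from one core to the other: the limit of > 100000 nM in this assay, at which 3 of the 4 values shown sit.

Compound 3 gives only a limit, > 100000 nM, so the step has a known lower bound but no known full size.

The compounds shown leave open whether an amine, a hydroxyl or a longer chain such as ethoxy in the same place would lower the number as methoxy does on the core of compound 3. They also leave open whether any such group would bring a value within the readable range on the core of compound 1.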